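A few compounds are considered here, and "the series" means these few. Any claim that something is new, unique, unknown or untested is made for them only; others in the source may bear on it.

Going by the values given here, compound 2 `O=C(N[C@H]1CN(S(=O)(=O)c2ccccc2)C[C@@H]1C(=O)N[C@H]1CCCNC1)c1cc(-c2ccccc2Cl)on1` is the stronger of the two compounds measured so far in a functional assay on HEK293 cells for agonist activity at growth hormone secretagogue receptor type 1 (Homo sapiens), read by HTRF and inositol phosphate accumulation, with a stated time of 90 min, in the presence of a further agent that is not named here; on this read-out higher numbers stand for larger maximal responses and lower numbers for smaller maximal responses: in this assay compound 2 gives 98%, whereas compound 1 `Cc1csc(C(=O)N[C@H]2CN(S(=O)(=O)c3ccccc3)C[C@@H]2C(=O)N[C@H]2CCCNC2)n1` gives 63%. Among the compounds with values here, the one measured step, a number 35 percentage points higher from compound 1 to compound 2 (beyond the scatter), came from exchanging the group on the carbonyl carbon: a group of 12 heavy atoms with one five-membered aromatic ring with 2 hetero atoms and one six-membered aromatic ring of carbon only in place of a group of 6 heavy atoms with one five-membered aromatic ring with 2 hetero atoms. Compound 3 `CN(C(=O)[C@H]1CN(S(=O)(=O)c2ccccc2)C[C@@H]1NC(=O)c1cc(-c2ccccc2Cl)on1)[C@H]1CCCNC1` keeps that larger group and differs from compound 2 only by methyl in place of hydrogen on an amide-type nitrogen. Within the data shown here, no measured step touches this amide-type nitrogen, so that step offers no direct guide; the change is small and the maximal response of compound 2 already sits high. Compound 3 is therefore expected to give about 88% in this assay, within 55% to 105%, which means an expected step of a number 10 percentage points lower from compound 2 to compound 3 (within the scatter), most likely not beyond the scatter.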

Compound 3, largest response reached (Emax), in percent of the reference or control that the assay uses: 88%
For compound 3 middle estimate and measured number coincide at the digits printed; the measured number falls inside the stated range.
By their numbers in this assay, from the lowest: compound 1; then compounds 3 and 2 (each within the scatter of the next).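

In this assay, methyl in place of hydrogen on an amide-type nitrogen gives a number 10 percentage points lower from compound 2 to compound 3 (within the scatter) and so stays within the usual variation. Going by these compounds alone, this is the first measured change at this nitrogen, whose other neighbours are a carbonyl carbon and a saturated ring carbon, and it shows that the amide hydrogen is not needed for a maximal response of this size in the pair of compound 2 and compound 3. No supporting evidence bears on this result, so it stays an observation without an explanation.

The compounds shown leave open whether a group larger than methyl on this nitrogen, such as an ethyl group or a longer chain ending in an amine or a carboxylic acid, would give a similar response. They also leave open whether methyl at this nitrogen would have the same outcome with the smaller group of compound 1 on the carbonyl carbon.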